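From Diethylamino to a Carboxy-Hydroxypyrrolidine Side Chain

The compounds below may be only part of what the source reports. "The series", "measured", "known", "first", "only" and "open" are said of these compounds alone.

Of the compounds shown here, two have been measured in a functional assay on HL-60 cells (Homo sapiens) for inhibition, read by MTT assay, with a stated time of 48 h, tested at 10 uM; a lower number here means less inhibition of growth, a higher number more inhibition of growth at the concentration tested. In that test, compound 1 (`Cc1cc(=O)c2c(O)cc(OCc3ccc([N+](=O)[O-])cc3)c([C@H]3CCN(C)C[C@H]3O)c2o1`) gives 14%, while compound 2 (`CCN(CC)Cc1c(O)c([C@H]2CCN(C)C[C@H]2O)c2oc(C)cc(=O)c2c1O`) gives 47%. Compound 2 therefore holds the higher of the two numbers, and the gap between them lies beyond the scatter.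

Compound 3 (`Cc1cc(=O)c2c(O)c(CN3CC(O)CC3C(=O)O)c(O)c([C@H]3CCN(C)C[C@H]3O)c2o1`) has not yet been measured. It differs from compound 2 in one place: 2-carboxy-4-hydroxypyrrolidin-1-yl in place of diethylamino on a saturated chain carbon bound to an aromatic carbon. Here, 2-carboxy-4-hydroxypyrrolidin-1-yl stands in place of diethylamino on a saturated chain carbon bound to an aromatic carbon.

Among the measured compounds shown here, no measured pair isolates this change, so any forecast rests on thin evidence. Compound 1, at 14%, shows only that a much lower number is possible among these compounds. Given how much the side chain changes, a downward step is expected, probably beyond the scatter, although a result close to compound 2 cannot be excluded. The expected step is a number 20 percentage points lower from compound 2 to compound 3 (beyond the scatter). For compound 3, the estimated value is 27%, with an expected range from 8% to 48%.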

Compound 3, percent growth inhibition at one concentration: 28%
For compound 3 the middle estimate is 1 percentage points below the measured one, and the stated range covers the measured number.
By their numbers in this assay, from the lowest: compound 1; then compound 3; then compound 2.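

In this assay, among the compounds shown here, this position proves sensitive to what it carries: putting 2-carboxy-4-hydroxypyrrolidin-1-yl in place of diethylamino on a saturated chain carbon bound to an aromatic carbon gives a number 19 percentage points lower from compound 2 to compound 3 (beyond the scatter), the first direct reading of a change at this place. The step does not abolish the effect, as compound 3 still gives 28% at the tested concentration, even though the entering group is larger and contains a five-membered non-aromatic ring. No available measurement bears on what lies behind this drop.

Because the ring, the carboxylic acid and the hydroxyl group enter together, the compounds shown leave open which of them accounts for the lower number. A plain pyrrolidin-1-yl group, or a 2-carboxypyrrolidin-1-yl group lacking the hydroxyl, on the same carbon would begin to separate these parts, while a piperidin-1-yl or morpholin-4-yl group would show whether other cyclic amines follow the same course.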